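A few compounds are considered here, and "the series" means these few. Any claim that something is new, unique, unknown or untested is made for them only; others in the source may bear on it.

Working notes on the series, read in a physicochemical assay for solubility, at pH 6.8; on this read-out lower numbers stand for lower solubility and higher numbers for higher solubility. Within the data shown here, compound 1 `O=c1c(Cl)c(COc2cccc(OCC3CCOCC3)c2)[nH]c2ccccc12` gives 2000 nM, the only full number so far. Compound 2 `CCCCCCCCCc1[nH]c2ccccc2c(=O)c1C` reads < 1000 nM, which is a limit of the assay. Compound 3 `O=c1cc(COc2cccc(OCC3CCOCC3)c2)[nH]c2ccccc12` differs from compound 1 in one place: hydrogen in place of chloro on an aromatic carbon, with hydrogen in place of chloro on an aromatic carbon. Among the measured compounds shown here, no measured pair shows this change, so any expectation in this assay rests on the structural change alone. The expected step of a 1.5-fold higher number from compound 1 to compound 3 (0.18 log units; within the scatter) is a small rise, not clearly beyond the scatter. For compound 3 the estimated value is 3000 nM, with an expected range from 1200 nM to 10000 nM.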

Compound 3, solubility: 4000 nM
Compound 3: the middle estimate sits 1.3-fold (0.12 log units) below what was measured; low and high end bracket the measured number.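

In this assay, hydrogen in place of chloro on this aromatic carbon, two atoms from the ring nitrogen, gives a 2.0-fold higher number from compound 1 to compound 3 (0.30 log units; within the scatter). Among these compounds, this is the first pair that differs in one place, and it shows no change beyond the scatter at this position. Compound 2 alone carries a limit of the assay: the limit of < 1000 nM in this assay, at which 1 of the 3 values shown sits.

Still open, from the compounds shown here alone, is whether another group on this carbon, such as a nitrile or an amine, would give a step beyond the scatter. A single pair also leaves open whether the same change reads alike with a different side chain on the shared core.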